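The compounds below may be only part of what the source reports. "The series", "measured", "known", "first", "only" and "open" are said of these compounds alone.

Of the compounds shown here, two have numbers so far. In a functional assay on the whole organism (strain Sprague-Dawley) for inhibition, with Rattus norvegicus as the target, with a stated time of 10 min (a higher number here means that more compound is needed for the effect, a lower number that less compound is needed), compound 1 `CCOc1ccccc1-c1ncc(C(=O)O)c(=O)[nH]1` gives 0.5 mg/kg and compound 2 `CCOc1ccc(OC)cc1-c1ncc(C(=O)O)c(=O)[nH]1` gives 0.2 mg/kg, the lower of the two. Compound 3 `CCOc1ccc(C(=O)O)cc1-c1ncc(C(=O)O)c(=O)[nH]1` has carboxy in place of methoxy on an aromatic carbon, para to an ethoxy group: carboxy in place of methoxy on an aromatic carbon. Among the measured compounds shown here, the only measured step at this carbon is a 2.5-fold lower number from compound 1 to compound 2 (0.40 log units; beyond the scatter), where methoxy took the place of hydrogen, a modest change beyond the scatter. For the measured compounds named here, no measured compound carries carboxy there, so that step gives a scale and no direct precedent. On that scale, a modest to somewhat larger move toward a higher number is expected in this assay, though the direction remains uncertain. The expected change is a 5.0-fold higher number from compound 2 to compound 3 (0.70 log units; beyond the scatter). For compound 3 the estimate is 1 mg/kg, with an expected range of 0.2 mg/kg to 5 mg/kg.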

Compound 3, dose for 50% inhibition: 25 mg/kg
Beside the measured number, compound 3's estimate is 25-fold (1.40 log units) below it, and the stated range ends below it.
By their numbers in this assay, from the lowest: compound 2; then compound 1; then compound 3.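

In this assay the carbon para to an ethoxy group proves far from indifferent to its substituent, since carboxy in place of methoxy gives a 130-fold higher number from compound 2 to compound 3 (2.10 log units; beyond the scatter) and runs opposite in direction to the modest effect of methoxy. Measured against hydrogen, carboxy still gives a 50-fold higher number from compound 1 to compound 3 (1.70 log units; beyond the scatter) so the large loss does not simply reflect removal of methoxy, and among the three groups seen here carboxy alone brings a large rise in the dose needed. Nothing available explains the size of this change.

Open, from the compounds shown here alone, is whether a methyl ester, a primary amide or an amine on this carbon would stay close to compound 2 or move toward compound 3. Also open, going by these compounds, is whether a longer alkoxy chain there would lower the number further than methoxy does.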